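A Second Nitro Group Added to the Aryl Ring

The compounds below may be only part of what the source reports. "The series", "measured", "known", "first", "only" and "open" are said of these compounds alone.

Compound 1 `COC(=O)C[C@H](NC(=O)/C(C#N)=C/c1cccc(Br)n1)c1ccccc1` gives 3100 nM
Compound 2 `CCC[C@H](NC(=O)/C(C#N)=C/c1ccc([N+](=O)[O-])cc1)c1ccccc1` gives 2940 nM

Both were tested in a functional assay on MM1 cells (Homo sapiens) for antiproliferative activity, read by MTT assay, with a stated time of 72 h; on this read-out higher numbers stand for weaker inhibition and lower numbers for stronger inhibition. Compound 2 stands lowest of the two numbers, yet compound 1 lies within the scatter of it, so the two cannot be told apart. Compound 3 `CCC[C@H](NC(=O)/C(C#N)=C/c1ccc([N+](=O)[O-])cc1[N+](=O)[O-])c1ccccc1` differs from compound 2 by nitro in place of hydrogen on an aromatic carbon. Going by the values given here, no measured pair shows this change, so there is nothing to set a direction from; the step is expected to stay within the scatter, as a 1.1-fold lower number from compound 2 to compound 3 (0.05 log units; within the scatter). Compound 3 is therefore estimated at 2600 nM, with a range from 900 nM to 7500 nM.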

Compound 3, half-maximal inhibitory concentration: > 10000 nM
Compound 3: a limit, no number; the forecaster's own chance of this, stated with the estimate: 5%; middle value at least 3.8-fold (0.58 log units) from the limit.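

In this assay, a nitro group ortho to a large group and meta to the first nitro group is not a neutral change: the data give an at least 3.4-fold higher number from compound 2 to compound 3 (0.53 log units; beyond the scatter) for this single swap. Going by these compounds alone, no earlier compound showed that this place on the aromatic ring can cost activity. Compound 3 gives > 10000 nM as a limit and not a number, so the full size of the loss stays unknown: the limit of > 10000 nM in this assay, at which 1 of the 3 values shown sits.

From the compounds shown here alone, whether fluorine, a methyl group or an amine would be tolerated at this place stays open. So does whether the loss follows the place itself or the nitro group.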